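The source may report more compounds than this note shows. Statements on the series, on what has been measured and on what is new or still open speak of the compounds shown alone.

Measured so far:

Compound 1 `O=C(CSc1ncccn1)N/N=c1/scc(-c2ccc(Br)cc2)n1-c1ccccc1` gives 273 ug/mL in an ADME assay on NIH3T3 cells (Mus musculus) for cytotoxicity, read by MTT assay, with a stated time of 24 h; a lower number here means a stronger inhibitor, a higher number a weaker inhibitor.
Compound 2 `N#Cc1ccc(-c2cs/c(=N/NC(=O)CSc3ncccn3)n2-c2ccccc2)cc1` gives < 3.9 ug/mL in this assay, a limit of the assay rather than a number.

Compound 1 carries the only number among these two values; the other value is a limit (the limit of < 3.9 ug/mL in this assay, at which 1 of the 2 values shown sits). Going by the values given here, the step of an at least 70-fold lower number from compound 1 to compound 2 (1.84 log units; beyond the scatter) is the only measured step, and it concerns a change on an aromatic carbon, cyano in place of bromo.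

Compound 3 `O=C(CSc1nnnn1-c1ccccc1)N/N=c1/scc(-c2ccc(Br)cc2)n1-c1ccccc1` is not yet measured. It differs from compound 1 in this way: 1-phenyl-1H-tetrazol-5-yl in place of pyrimidin-2-yl on a sulfur. Among the compounds with values here, the measured step from compound 1 to compound 2 touches a different part of the shared core, so no measured step bears on this change, and the data give no ground to expect a step beyond the scatter in either direction.

Compound 3 is therefore expected to land near compound 1 in this assay, estimated at 200 ug/mL (range 30 ug/mL to 500 ug/mL), an expected step of a 1.4-fold lower number from compound 1 to compound 3 (0.14 log units; within the scatter).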

Compound 3, half-maximal inhibitory concentration: 433 ug/mL
Compound 3: middle estimate off by 2.2-fold (0.34 log units), on the low side, within the range that was stated.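

In this assay, the position on the sulfur proves open to a large exchange: 1-phenyl-1H-tetrazol-5-yl, with 11 heavy atoms, in place of pyrimidin-2-yl, with 6, gives a 1.6-fold higher number from compound 1 to compound 3 (0.20 log units; within the scatter). Going by these compounds alone, the only earlier step concerned a change on an aromatic carbon, so this is the first evidence that the group on the sulfur can be enlarged, with a carbon-only aromatic ring added, while the number stays within the scatter in a compound carrying bromo. Nothing in the information given bears on the reason for this result.

From the compounds shown here alone, what an amine or a carboxylic acid on that sulfur would give remains open. Going by these compounds, it is also open whether 1-phenyl-1H-tetrazol-5-yl would behave in the same way in a compound carrying cyano in place of bromo.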